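A thiophene in place of the cyanophenyl

The source may hold more compounds than are shown below. What is called first, only, known or untested is meant among the compounds shown, and "the series" means these compounds.

Compound 1 `CC/C(=C(/c1ccc(/C=C/C(=O)O)cc1)c1ccc2[nH]ccc2c1)c1ccccc1`: 9 nM
Compound 2 `CC/C(=C(/c1ccc(/C=C/C(=O)O)cc1)c1ccc2[nH]ncc2c1)c1ccccc1C#N`: 12 nM

Both compounds were tested in a functional assay on MCF7 cells (Homo sapiens) for cytotoxicity, read by CellTiter-Glo, with a stated time of 5 days; on this read-out higher numbers stand for weaker inhibition and lower numbers for stronger inhibition. Compound 2 gives the larger of the two numbers, but compound 1 sits so close that the gap between them lies within the usual scatter of repeated measurements, so the two cannot be told apart on these data. Compound 3 `CC/C(=C(/c1ccc(/C=C/C(=O)O)cc1)c1ccc2[nH]ncc2c1)c1cscc1C` has not yet been measured in this assay. It differs from compound 2 in one place: 4-methylthiophen-3-yl in place of 2-cyanophenyl on a double-bonded chain carbon bound to a double-bonded chain carbon and a saturated chain carbon. No pair of measured compounds separates a change of this kind in this assay, so the only footing is the value of compound 2 itself. The step is expected to stay within the scatter, as a 1.3-fold higher number from compound 2 to compound 3 (0.10 log units; within the scatter). Compound 3 is therefore estimated at 15 nM in this assay, with a likely range from 5 nM to 45 nM.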

Compound 3, half-maximal inhibitory concentration: 2 nM
The estimate for compound 3 lay 7.5-fold (0.88 log units) above the measured number; measured number below the stated range.
By their numbers in this assay, from the lowest: compound 3; then compounds 1 and 2 (each within the scatter of the next).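

At the double-bonded chain carbon bound to a double-bonded chain carbon and a saturated chain carbon, the change to 4-methylthiophen-3-yl from 2-cyanophenyl moves the number in this assay clearly, with a 6.0-fold lower number from compound 2 to compound 3 (0.78 log units; beyond the scatter), whereas compounds 1 and 2 differed in more than one place and isolated no change here. The position therefore accepts a five-membered aromatic ring with one hetero atom in place of the six-membered carbon ring and its nitrile, and stronger inhibition comes with that swap in this single pair. Nothing available explains the step.

The pair cannot separate the loss of the nitrile from the change of ring or the arrival of the methyl. It also leaves open how a plain thiophen-3-yl, or an ethyl or chlorine in place of that methyl, would read in this assay.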